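Carbonyl substituent series: ester to benzylamide on shared core

The compounds below may be only part of what the source reports. "The series", "measured", "known", "first", "only" and "open" are said of these compounds alone.

Compound 1 `CCN(CC)C(=O)c1cc(-c2ccccc2)c2ccccc2c1` is the anchor of the set; in an assay on brain with Translocator protein (Rattus norvegicus) as the target (on this read-out lower numbers stand for stronger inhibition and higher numbers for weaker inhibition), compound 1 gives 5 nM. Compound 2 `CCN(Cc1ccccc1)Cc1nc2ccccc2c(-c2ccccc2)c1C(=O)N(CC)CC` in this assay gives 373 nM, and compound 3 `CCOC(=O)c1c(CN(CC)Cc2ccccc2)nc2ccccc2c1-c1ccccc1` in this assay gives 700 nM. Compound 3 therefore sits at the high end of the three numbers: its gap to compound 2 is within the scatter, whereas its distance from compound 1 is far beyond it.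

For the measured compounds named here, the only step touching the carbonyl carbon is a 1.9-fold higher number from compound 2 to compound 3 (0.27 log units; within the scatter), which is ethoxy in place of diethylamino, and it stayed within the scatter. Compound 4 `CCN(Cc1ccccc1)Cc1nc2ccccc2c(-c2ccccc2)c1C(=O)NCc1ccccc1` carries the next change there: benzylamino in place of ethoxy on a carbonyl carbon. Going by the values given here, no measured pair puts a ring-bearing group on that carbonyl carbon, so the data give no direction for it; the one precedent at this position argues for little movement. The expected step is a 1.2-fold lower number from compound 3 to compound 4 (0.07 log units; within the scatter), that is, none beyond the scatter. Compound 4 in this assay is estimated at 600 nM, with a range from 150 nM to 2500 nM.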

Compound 4, half-maximal inhibitory concentration: 2900 nM
Estimate against measurement, compound 4: 4.8-fold (0.68 log units) below; the whole stated range lies below it.
By their numbers in this assay, from the lowest: compound 1; then compounds 2 and 3 (each within the scatter of the next); then compound 4.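

The carbonyl carbon is not indifferent to the group it carries: in this assay benzylamino gives a 4.1-fold higher number from compound 3 to compound 4 (0.62 log units; beyond the scatter) and a 7.8-fold higher number from compound 2 to compound 4 (0.89 log units; beyond the scatter) and so moves the number beyond the scatter, towards weaker inhibition, which the swap of ethoxy and diethylamino did not do. Among the groups shown on this carbon, benzylamino alone brings both a six-membered aromatic ring and a hydrogen-bond donor, so the two changes cannot be separated here. No evidence in hand accounts for this step.

As far as these compounds go, it remains open whether the ring or the amide hydrogen goes with the higher number; ethylamino and benzyl(methyl)amino on the same carbonyl carbon would separate the two. A carboxylic acid at this carbon and a longer chain between the amide nitrogen and the phenyl ring are also untested in the compounds shown.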